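The compounds below may be only part of what the source reports. "The series", "measured", "known", "first", "only" and "open" are said of these compounds alone.

In a functional assay on the whole organism with Mus musculus as the target (a lower number here means that less compound is needed, a higher number that more compound is needed for the effect), three compounds have been measured so far. Compound 1 `Cc1c(C)c2c(c([N+](=O)[O-])c1N)CC(C)(C)O2` is reported only as the limit > 100 mg/kg and not as a number. Compound 2 `Cc1c(C)c2c(c(C)c1N)CC(C)(Cn1ccnc1)O2` gives a true number of 25 mg/kg in this test. As far as these compounds go, compound 3 `CC(=O)Nc1c(C)c(C)c2c(c1C)CC(C)(C)O2` is also reported only as a limit, > 100 mg/kg, so its exact position is unknown.

Compound 4 `CCNc1c(C)c(C)c2c(c1C)CC(C)(C)O2` carries ethyl in place of acetyl on a nitrogen on an aromatic ring, turning acetamido to ethylamino (ethyl in place of acetyl on a nitrogen on an aromatic ring). Going by the values given here, no measured pair shows this change directly, so the size of the step is uncertain. Among the compounds with values here, a move to a lower number, beyond the usual scatter, is expected, with compound 2 at 25 mg/kg as the only numerical guide. The expected step runs an at least 2.5-fold lower number from compound 3 to compound 4 (0.39 log units; beyond the scatter) on this estimate. For compound 4 the estimated value is 40 mg/kg with an expected range from 12 mg/kg to 100 mg/kg in this test.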

Compound 4, dose for 50% inhibition: 38.9 mg/kg
Compound 4: the middle estimate sits 1.0-fold (0.01 log units) above what was measured; the measured number falls inside the stated range.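

In this assay the nitrogen on the aromatic ring proves sensitive to what it carries: ethyl in place of acetyl gives an at least 2.5-fold lower number from compound 3 to compound 4 (0.41 log units; beyond the scatter) on the shared core. Going by these compounds alone, this is the first change in one place that leads from a limit to a true number. As far as these compounds go, the full size of the step stays unknown because compound 3 is reported only as a limit: the limit of > 100 mg/kg in this assay, at which 2 of the 4 values shown sit.

From the compounds shown here alone, whether the ethyl itself matters or only the loss of the carbonyl stays open. Methyl or a longer chain such as propyl on this nitrogen would help separate the two.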